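This account rests on a few compounds, and the source may have more. Where it says the series, first, only, none or still open, it means among the compounds named here.

Compound 1 `O=C(NC[C@H](NS(=O)(=O)c1ccccc1)C(=O)O)c1cc2cc(CCC3CCNCC3)sc2s1`: 8 nM
Compound 2 `O=C(NC[C@H](NS(=O)(=O)c1cccs1)C(=O)O)c1cc2sc(CCC3CCNCC3)cc2s1`: 13 nM
Compound 3 `O=C(NC[C@H](NS(=O)(=O)c1ccccc1)C(=O)O)c1cc2sc(CCC3CCNCC3)cc2s1`: 8 nM

In a functional assay for inhibition, with Homo sapiens as the target (on this read-out higher numbers stand for weaker inhibition and lower numbers for stronger inhibition), compound 3 at 8 nM stands level with compound 1 and within the scatter of compound 2. Compound 4 `O=C(NCc1ccccc1)N[C@@H](CNC(=O)c1cc2sc(CCC3CCNCC3)cc2s1)C(=O)O` differs from compound 3 as follows: benzylcarbamoyl in place of phenylsulfonyl on an amine nitrogen. Within the data shown here, the only measured step, a 1.6-fold lower number from compound 2 to compound 3 (0.21 log units; within the scatter), lies within the scatter, but it exchanges phenyl for thiophen-2-yl on a sulfonyl sulfur and leaves the sulfonyl in place. Among the measured compounds shown here, no measurement yet shows what replacing the phenylsulfonyl does, so only a modest shift towards a higher number is expected, and with wide uncertainty. The expected step is a 2.5-fold higher number from compound 3 to compound 4 (0.40 log units; beyond the scatter). For compound 4 the estimated value is 20 nM, with an expected range from 6 nM to 70 nM.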

Compound 4, half-maximal inhibitory concentration: 36 nM
Estimate against measurement, compound 4: 1.8-fold (0.26 log units) below; measured number inside the range.
By their numbers in this assay, from the lowest: compounds 1, 3 and 2 (each within the scatter of the next); then compound 4.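

Replacing the whole sulfonyl on the amine nitrogen with benzylcarbamoyl moves the number in this assay beyond the scatter, whether the starting point is phenylsulfonyl (a 4.5-fold higher number from compound 3 to compound 4 (0.65 log units; beyond the scatter)) or (thiophen-2-yl)sulfonyl (a 2.8-fold higher number from compound 2 to compound 4 (0.44 log units; beyond the scatter)). The earlier step changed only the ring on the sulfonyl sulfur and stayed within the scatter, so this position responds more to the linking group than that step could show. Nothing at hand explains the shift. On these data alone, it remains open whether a methylsulfonyl or a benzyloxycarbonyl on this nitrogen would read like the sulfonyl compounds or like compound 4.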